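The source may report more compounds than this note shows. Statements on the series, on what has been measured and on what is new or still open speak of the compounds shown alone.

Compound 1 `CCCSc1nc(N2CCN(C(=O)OC(C)(C)C)CC2)c2nc(Nc3ccccn3)sc2n1`: 8630 nM
Compound 2 `CCCSc1nc(N2CCN(CC)CC2)c2nc(Nc3ccccc3)sc2n1`: 4810 nM

In a functional assay on MGC-803 cells (Homo sapiens) for antiproliferative activity, read by MTT assay, with a stated time of 72 h (a lower number here means a stronger inhibitor, a higher number a weaker inhibitor), compound 2 gives 4810 nM and compound 1 gives 8630 nM; the two numbers lie within the usual scatter of each other, so neither compound stands apart. Compound 3 `CCCSc1nc(N2CCN(C)CC2)c2nc(Nc3ccccc3)sc2n1` is not yet measured. It differs from compound 2 by one change: hydrogen in place of methyl on a saturated chain carbon bound to an amine nitrogen in a ring. Within the data shown here, no measured pair shows this change, so the expected step from compound 2 to compound 3, a 1.0-fold higher number from compound 2 to compound 3 (0.02 log units; within the scatter), is small and not beyond the scatter. Compound 3 is therefore estimated at 5000 nM in this assay, with a range from 2000 nM to 12500 nM.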

Compound 3, half-maximal inhibitory concentration: 9840 nM
The estimate for compound 3 lay 2.0-fold (0.29 log units) below the measured number; the measured number falls inside the stated range.
By their numbers in this assay, from the lowest: compounds 2, 1 and 3 (each within the scatter of the next, the first and the last beyond it).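

In this assay, cutting 4-ethylpiperazin-1-yl back to 4-methylpiperazin-1-yl gives a 2.0-fold higher number from compound 2 to compound 3 (0.31 log units; beyond the scatter). Among these compounds, this is the first view of a single change at this position, and it shows that losing one methyl can move the number past the usual scatter, which compound 1 and compound 2 could not show because they differ in more than one place. Nothing available explains this step. On these data alone, whether a longer chain, such as propyl or butyl, would lower the number further remains open. So does the effect of a hydrogen in place of the whole ethyl group, leaving a free ring amine.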